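Carbamoylmethyl for Isopropyl in an Oral Tail Flick Series

The compounds below may be only part of what the source reports. "The series", "measured", "known", "first", "only" and "open" are said of these compounds alone.

Two compounds sharing an amide-linked core and a benzyl ester have been tested in a functional assay on the whole organism (Tail, strain ICR) with Mus musculus as the target, in the tail flick test, with a stated time of 30 min, at a dose of 25 umol/kg by the oral route; a higher number here means a stronger effect of the compound at the dose given, a lower number a weaker effect. Compound 1 `N=C(N)NCCC[C@H](NC(=O)CN(c1ncnc2c1ncn2C1CCCCO1)C1CC1)C(=O)OCc1ccccc1` gives 34.3% in this assay. Going by the values given here, compound 2 `CC(C)C[C@H](NC(=O)CN(c1nc(Cl)nc2[nH]cnc12)C1CC1)C(=O)OCc1ccccc1` gives 33.9% in this assay, the lower of the two numbers, yet its only neighbour, compound 1, lies within the scatter of it, so no order between them can be read. Compound 3 `NC(=O)CC[C@H](NC(=O)CN(c1nc(Cl)nc2[nH]cnc12)C1CC1)C(=O)OCc1ccccc1` has not yet been measured. It differs from compound 2 in one place: carbamoylmethyl in place of isopropyl on a saturated chain carbon, two bonds along the chain from an amide-type nitrogen and a carbonyl carbon. The two measured compounds carry different side chains on that chain carbon and still give numbers within the scatter of each other, so the step of a number 0.9 percentage points lower from compound 2 to compound 3 (within the scatter) is expected to be none beyond the scatter. For compound 3 the estimate in this assay is 33%, expected to fall between 15% and 50%.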

Compound 3, a percentage reported as activity, at one dose (the size of the read-out at that dose, not a potency): 30.8%
Compound 3: middle estimate off by 2.2 percentage points, on the high side, and the stated range covers the measured number.
By their numbers in this assay, from the lowest: compounds 3, 2 and 1 (each within the scatter of the next).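

In this assay, going by these compounds alone, carbamoylmethyl in place of isopropyl on a saturated chain carbon, two bonds along the chain from an amide-type nitrogen and a carbonyl carbon, gives a number 3.1 percentage points lower from compound 2 to compound 3 (within the scatter), the first comparison at this position in which nothing else differs. Isopropyl has 0 hydrogen-bond donors and 0 hydrogen-bond acceptors, whereas carbamoylmethyl has 1 of each, yet the two read-outs at this one dose stay within the scatter of each other. Nothing available explains this result.

On these data alone, whether a primary amine, a carboxylic acid or a longer chain at this position would also stay within the scatter of compound 2 remains open. A read-out at one dose and one time also leaves open whether compound 2 and compound 3 would stay this close at other doses or times.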